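The compounds below may be only part of what the source reports. "The series", "measured", "known", "first", "only" and "open" are said of these compounds alone.

Series notes, cytotoxicity in a functional assay on A-431 cells (Homo sapiens) for cytotoxicity, read by MTT assay, with a stated time of 48 h; a lower number here means a stronger inhibitor, a higher number a weaker inhibitor:

compound 1, `CCCCCCCCNC(=O)[C@@H](NC(=O)c1cccs1)[C@@H](C)O`: 32200 nM
compound 2, `CCCCCCCCCCCCNC(=O)[C@@H](NC(=O)c1cccs1)[C@@H](C)O`: 16600 nM
compound 3, `CCCCCCCCCCCCCCNC(=O)[C@@H](NC(=O)c1cccs1)[C@@H](C)O`: 26500 nM

The three measured compounds share one core and differ only in the length of the saturated chain on the amide-type nitrogen. The steps among them read a 1.9-fold lower number from compound 1 to compound 2 (0.29 log units; within the scatter), a 1.2-fold lower number from compound 1 to compound 3 (0.08 log units; within the scatter) and a 1.6-fold higher number from compound 2 to compound 3 (0.20 log units; within the scatter), every one within the scatter. Compound 3 therefore cannot be separated from either neighbour on these numbers: its nearest is compound 1 and its furthest is compound 2, and both gaps stay inside the noise of repeated measurement.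

Compound 4, `C/C=C/C=C/C(=O)N[C@H](C(=O)NCCCCCCCCCCCCCC)[C@@H](C)O`, keeps the chain of compound 3 and changes the other end: penta-1,3-dien-1-yl in place of thiophen-2-yl on a carbonyl carbon. Going by the values given here, no measured step touches this carbonyl substituent; all three concern the chain, so none bears directly on the exchange, and the data give no direction for it. What the chain steps do show is that this series has so far moved only within the scatter. Lacking any step on the carbonyl side, the default expectation is a step of a 1.1-fold lower number from compound 3 to compound 4 (0.03 log units; within the scatter) in this assay, with a wide range to cover the unknown. Compound 4 is estimated at 25000 nM, between 7000 nM and 90000 nM.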

Compound 4, half-maximal inhibitory concentration: > 200000 nM
Compound 4 was reported as a limit (the forecaster's own chance of this, stated with the estimate: 10%); middle value at least 8.0-fold (0.90 log units) from the limit.
By their numbers in this assay, from the lowest: compounds 2, 3 and 1 (each within the scatter of the next). At a limit, above all of these: compound 4.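

Going by these compounds alone, the carbonyl substituent is the first place where a single exchange moves the read-out beyond the scatter: in this assay, penta-1,3-dien-1-yl in place of thiophen-2-yl on a carbonyl carbon gives an at least 7.5-fold higher number from compound 3 to compound 4 (0.87 log units; beyond the scatter), whereas all three chain steps stay within the scatter. Compound 4 is reported only as a limit, not as a number: the limit of > 200000 nM in this assay, at which 1 of the 4 values shown sits. With the chain of compound 3 held fixed, the carbonyl side therefore matters more in this assay than any chain change shown so far, and thiophen-2-yl is the one of the two groups that gives a value short of the limit.

Open, from the compounds shown here alone, is which part of the exchange carries the loss, the five-membered aromatic ring, its sulfur or the 2 double bonds outside aromatic rings, and a saturated pentyl group, a phenyl ring or a furan-2-yl ring on the same carbonyl carbon would help to separate these. Also open, going by these compounds, is whether the exchange reads the same on the shorter chains of compound 1 and compound 2.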